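A few compounds are considered here, and "the series" means these few. Any claim that something is new, unique, unknown or untested is made for them only; others in the source may bear on it.

Within the data shown here, compound 1 `O=C(C1CCN(C(=O)C(F)(F)F)CC1)N1N=CCC1c1ccccc1` is the one compound of this set that gives a number in an ADME assay on microsomes (Rattus norvegicus) for metabolic stability; on this read-out lower numbers stand for a shorter-lived compound and higher numbers for a longer-lived compound: in that assay compound 1 gives 0.483 h. Compound 2 `CC(C)(C)C(=O)N1N=CCC1c1cccnc1` reaches only a limit of the assay in this assay, reported as > 1.5 h. Compound 3 `O=C(c1cnco1)N1CCC(C(=O)N2N=CC[C@H]2c2ccccc2)CC1` likewise reaches only a limit in this assay, reported as > 3 h. Among the measured compounds shown here, compound 1 therefore stands apart as the single measured number, with the other two values being limits. Compound 4 `O=C(c1c[nH]nn1)N1CCC(C(=O)N2N=CCC2c2ccccc2)CC1` is not yet measured; it differs from compound 1 by 1H-1,2,3-triazol-4-yl in place of trifluoromethyl on a carbonyl carbon. For the measured compounds named here, no pair of measured compounds differs in one place, so no measured step sets the size of this change. Compound 4 is expected to move toward the longer-lived end, by a 3.1-fold higher number from compound 1 to compound 4 (0.49 log units; beyond the scatter). The half-life of compound 4 is estimated at 1.5 h, between 0.5 h and 4 h.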

Compound 4, half-life: > 2.75 h
Compound 4 was reported as a limit; the forecaster's own chance of this, stated with the estimate: 40%; middle value at least 1.8-fold (0.26 log units) away from the limit.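

In this assay, among these compounds, the swap of trifluoromethyl for 1H-1,2,3-triazol-4-yl on a carbonyl carbon gives an at least 5.6-fold higher number from compound 1 to compound 4 (0.75 log units; beyond the scatter) and so sets the first measured step at this position, one beyond the scatter. That figure is only a lower bound on the size of the change, because the value for compound 4 is a limit of the assay: the limit of > 2.75 h in this assay, at which 1 of the 4 values shown sits. On these data alone, how far compound 4 lies past that limit stays open. As far as these compounds go, whether an amine or a carboxylic acid on this carbonyl carbon would also give a higher number than compound 1 stays open too.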